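A few compounds are considered here, and "the series" means these few. Any claim that something is new, unique, unknown or untested is made for them only; others in the source may bear on it.

Measured so far in an assay on cells for displacement of a labelled ligand from adenosine receptor A1 (Homo sapiens), read by scintillation counting and radioligand binding, with a stated time of 60 min, tested at 10 uM; a lower number here means less inhibition, a higher number more inhibition at the concentration tested (going by the name of the read-out):
compound 1, `CN1CCN(c2nc(-c3cccc(Cl)c3)nc3[nH]cnc23)CC1`: > 80%
compound 2, `Oc1cccc(-c2nc(N3CCCCC3)c3nc[nH]c3n2)c1`: > 80%
compound 3, `Clc1ccc(Cl)c(-c2nc(N3CCCCC3)c3nc[nH]c3n2)c1`: 1.4%

The values of compound 1 and compound 2 are limits of this assay, not numbers. Compound 3 alone gives a number, and it lies far beneath the limit where the other two sit (the limit of > 80% in this assay, at which 2 of the 3 values shown sit). Among the compounds with values here, no two measured compounds differ in a single place, so no measured step is available.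

Compound 4, `Clc1cccc(-c2nc(N3CCCCC3)c3nc[nH]c3n2)c1`, is still to be measured. It differs from compound 3 by hydrogen in place of chloro on an aromatic carbon. Compound 1 also carries a single chloro and reaches a limit > 80%. For compound 4 a large upward step in this assay is expected, a number 73.6 percentage points higher from compound 3 to compound 4 (beyond the scatter), with the chance that only a limit is reported. Compound 4 is estimated at 75%, between 40% and 95%.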

Compound 4, a percentage reported as inhibition, at one concentration (the size of the read-out at that concentration, not a potency): > 80%
Compound 4 gave a limit, no number; the forecaster's own chance of this, stated with the estimate: 45%; middle value at least 5 percentage points away from the limit.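

In this assay, within the data shown here, hydrogen in place of chloro on an aromatic carbon, ortho to a large group and para to a chloro group, gives a number at least 78.6 percentage points higher from compound 3 to compound 4 (beyond the scatter) as the first step that can be read at a single place. This one position alone is thus enough for a large change in the read-out, with the rest of the structure held. Compound 4 stands at a limit, not a number, so the step is bounded from one side only.

From the compounds shown here alone, whether a fluoro, methyl or methoxy group at this position keeps the read-out at the limit stays open. The steps from compound 1 and from compound 2 to compound 4 cannot be read, because both ends of each are limits: the limit of > 80% in this assay, at which 3 of the 4 values shown sit.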